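Carboxy in place of phenyl: expectation in the HDAC6 assay

The compounds below may be only part of what the source reports. "The series", "measured", "known", "first", "only" and "open" are said of these compounds alone.

Working notes on the series. Compound 1 `CC(C)(C)OC(=O)N1C(NCc2ccc(C(=O)Nc3ccccc3N)cc2)=NC(=O)C1Cc1c[nH]c2ccccc12` and compound 2 `Nc1cc(-c2ccccc2)ccc1NC(=O)c1ccc(CNc2nccc(-c3cccnc3)n2)cc1` have both been tested in an assay on isolated protein for inhibition of protein deacetylase HDAC6 (Homo sapiens), read by fluorescence, with stated times of 3 h and 60 min; on this read-out higher numbers stand for weaker inhibition and lower numbers for stronger inhibition. Compound 1 returns only the assay limit, > 20000 nM. Compound 2 likewise returns only the assay limit, > 20000 nM. Within the data shown here, both results sit at the same limit, (the limit of > 20000 nM in this assay, at which 2 of the 2 values shown sit), so no step between measured compounds can be computed, and where compound 2 stands in this assay is known only as that limit, not as a number.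

Compound 3 `Nc1cc(C(=O)O)ccc1NC(=O)c1ccc(CNc2nccc(-c3cccnc3)n2)cc1` is the next compound. It differs from compound 2 in one place: carboxy in place of phenyl on an aromatic carbon. Among the measured compounds shown here, with no measured step available, the expectation rests on compound 2 alone, whose value in this assay is a limit rather than a number. The step expected in this assay is a number no higher from compound 2 to compound 3 (the limit leaves the size open), which is none beyond the scatter. Compound 3 is therefore expected to give about 20000 nM in this assay, with a range from 8000 nM to 60000 nM, and the result may well again come back only as a limit.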

Compound 3, half-maximal inhibitory concentration: > 20000 nM
Compound 3 ended at the assay's limit; the forecaster's own chance of this, stated with the estimate: 75%; the middle value lies on the limit itself.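

Compound 2 and compound 3 both return only a limit in this assay, so no step between them can be read for carboxy in place of phenyl on an aromatic carbon: the limit of > 20000 nM in this assay, at which 3 of the 3 values shown sit.

The compounds shown leave open what number any of the three would give, and whether this change moves the read-out at all.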